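Chain length between carbonyl and tetrazole on ileum potency

This account rests on a few compounds, and the source may have more. Where it says the series, first, only, none or still open, it means among the compounds named here.

Compound 1 `CCCc1c(COc2ccc(C(=O)C(C)Cc3nnn[nH]3)cc2)ccc(C(C)=O)c1O`: 7.18
Compound 2 `CCCc1c(COc2ccc(C(=O)C(C)(C)Cc3nnn[nH]3)cc2)ccc(C(C)=O)c1O`: 6.93
Compound 3 `CCCc1c(COc2ccc(C(=O)CCCc3nnn[nH]3)cc2)ccc(C(C)=O)c1O`: 7.67

In a functional assay on ileum (Cavia porcellus) with cysteinyl leukotriene receptor (Homo sapiens) as the target (on this read-out higher numbers stand for higher potency (the scale is a negative logarithm) and lower numbers for lower potency), compound 3 gives the highest of the three numbers, with a number 0.49 log units higher from compound 1 to compound 3 (beyond the scatter) and a number 0.74 log units higher from compound 2 to compound 3 (beyond the scatter) both beyond the scatter, while a number 0.25 log units lower from compound 1 to compound 2 (within the scatter) lies within it. Compound 4 `CCCc1c(COc2ccc(C(=O)CCCCCCc3nnn[nH]3)cc2)ccc(C(C)=O)c1O` differs from compound 3 by 3-(1H-tetrazol-5-yl)propyl in place of 1H-tetrazol-5-yl on a saturated chain carbon, three bonds along the chain from a carbonyl carbon. The measured steps concern branching on the chain, not its length, so none of them bears directly on this change; the two steps that do exist point only to an unbranched chain being favoured. On that basis the expected step of a number 0.37 log units lower from compound 3 to compound 4 (beyond the scatter) is small, with a slight downward lean. Compound 4 is therefore estimated at 7.3, expected between 6.6 and 8.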

Compound 4, negative logarithm of the antagonist equilibrium constant: 7.33
Compound 4: middle estimate off by 0.03 log units, on the low side, within the range that was stated.
By their numbers in this assay, from the lowest: compounds 2, 1 and 4 (each within the scatter of the next, the first and the last beyond it); then compound 3.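

In this assay the longer unbranched chain gives a number 0.34 log units lower from compound 3 to compound 4 (beyond the scatter) and so shows that chain length at this position matters, not only branching. Against the branched chains, 6-(1H-tetrazol-5-yl)hexyl gives a number 0.40 log units higher from compound 2 to compound 4 (beyond the scatter) and a number 0.15 log units higher from compound 1 to compound 4 (within the scatter) so added length gives up part of the edge that the unbranched chain of compound 3 holds over both. Nothing measured here explains these steps. Open, going by these compounds, is whether a shorter chain or a 5-(1H-tetrazol-5-yl)pentyl chain on the carbonyl carbon would do better. Also open, on these data alone, is how a carboxylic acid in place of the tetrazole would read.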